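The source may report more compounds than this note shows. Statements on the series, on what has been measured and on what is new or still open speak of the compounds shown alone.

Measured so far:
- compound 1, `COc1ncc(-c2ccc3ncnc(Nc4ccc(OCCO)cc4)c3c2)cc1NS(C)(=O)=O`: 3270 nM
- compound 2, `COC(=O)Cn1cc(Nc2ncnc3ccc(-c4cnc(OC)c(NS(=O)(=O)c5ccc(F)cc5F)c4)cc23)cn1`: 670 nM
- compound 3, `CCCCS(=O)(=O)Nc1cc(-c2ccc3ncnc(Nc4ccc(OCCO)nc4)c3c2)cnc1OC`: a limit, > 20000 nM

In a functional assay on MCF7 cells (Homo sapiens) for antiproliferative activity, read by sulforhodamine B assay, with a stated time of 72 h (a higher number here means a weaker inhibitor, a lower number a stronger inhibitor), compound 2 gives the lowest of the two numbers recorded; compound 1 sits at a higher number, a gap beyond the scatter. Compound 3 reports only a limit in this assay, (the limit of > 20000 nM in this assay, at which 1 of the 3 values shown sits), so it cannot be placed against the other two by a number.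

Compound 4, `COc1ncc(-c2ccc3ncnc(Nc4ccc(OCCCO)nc4)c3c2)cc1NS(=O)(=O)c1ccc(F)cc1F`, has not been measured. It differs from compound 2 in one place: 6-(3-hydroxypropoxy)pyridin-3-yl in place of 1-((methoxycarbonyl)methyl)-1H-pyrazol-4-yl on a nitrogen on an aromatic ring. The rest of the molecule, including the difluorophenylsulfonamide on the shared core, is kept.

Among the measured compounds shown here, no step between two measured compounds isolates this change. What the data do offer is that compound 3, which also carries a hydroxyalkoxy-pyridinyl amine on the same core, gives only a limit in this assay, while the two compounds with a number carry a different amine. On that basis the step from compound 2 to compound 4 is expected to run towards a higher number, and to be larger than the scatter, roughly a 5.2-fold higher number from compound 2 to compound 4 (0.72 log units; beyond the scatter).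

Compound 4 is therefore estimated at 3500 nM in this assay, with a range from 900 nM to 14000 nM.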

Compound 4, half-maximal inhibitory concentration: 6120 nM
Estimate against measurement, compound 4: 1.7-fold (0.24 log units) below; measured number inside the range.
By their numbers in this assay, from the lowest: compound 2; then compounds 1 and 4 (each within the scatter of the next). At a limit, above all of these: compound 3.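

The substituent on the nitrogen on an aromatic ring is now shown to matter on its own. Among the compounds shown here, with the difluorophenylsulfonamide and the rest of the molecule kept, 6-(3-hydroxypropoxy)pyridin-3-yl in place of 1-((methoxycarbonyl)methyl)-1H-pyrazol-4-yl gives a 9.1-fold higher number from compound 2 to compound 4 (0.96 log units; beyond the scatter) in this assay, the first single-place step in this set and one that favours the pyrazole group of compound 2. Compound 3 remains a limit, not a number, and gives no size for any step: the limit of > 20000 nM in this assay, at which 1 of the 4 values shown sits.

The step swaps the ring, the chain and the end group together, so it cannot say which of these carries the change, and a single pair gives no pattern for the position. A carboxylic acid in place of the methoxycarbonyl group on the pyrazole, or an amine in place of the hydroxyl at the end of the 3-hydroxypropoxy chain, would begin to separate these parts while the difluorophenylsulfonamide stays fixed.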